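The source may report more compounds than this note shows. Statements on the series, on what has been measured and on what is new or still open speak of the compounds shown alone.

Measured so far:
compound 1 `C=CCn1c(=O)/c(=C\c2cccc(Cl)c2Cl)[nH]c(=O)/c1=C\c1ccccc1OC`, a functional assay on BGC-823 cells (Homo sapiens) for cytotoxicity, read by CCK-8 assay, with a stated time of 72 h (a lower number here means a stronger inhibitor, a higher number a weaker inhibitor), 2200 nM
compound 2 `C=CCn1c(=O)/c(=C\c2ccc(Cl)c(Cl)c2)[nH]c(=O)/c1=C\c1ccccc1OC`, this assay "not active" (no number reported)

Compound 2 stands without a number in this assay: it is reported as "not active" (no number reported), whereas compound 1 gives 2200 nM. Within the data shown here, no step between the two can be stated, since one side has no value; the two results show only that compound 1 has a measurable half-maximal inhibitory concentration and compound 2 does not.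

Compound 3 `C=CCn1c(=O)/c(=C\c2ccccc2OC)[nH]c(=O)/c1=C\c1ccccc1OC` differs from compound 2 by 2-methoxyphenyl in place of 3,4-dichlorophenyl on a double-bonded chain carbon bound to an aromatic carbon. The change makes both arylidene arms of the shared core identical. Among the measured compounds shown here, with no measured step to rest on, the direction is open; an outcome anywhere from a measurable value in the range of compound 1 to a repeat of the inactive result of compound 2 is plausible.

Compound 3 is expected to give about 6000 nM in this assay. The expected range for compound 3 runs from 1000 nM to 40000 nM, with a real chance that only "not active" is reported.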

Compound 3, half-maximal inhibitory concentration: 13400 nM
Compound 3: middle estimate off by 2.2-fold (0.35 log units), on the low side; low and high end bracket the measured number.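

With compound 3, the place on a double-bonded chain carbon bound to an aromatic carbon is shown to carry a ring without chlorine and still give a number in this assay: compound 3 gives 13400 nM, while compound 2 is reported only as "not active", so the step between them cannot be read. Exchanging 2,3-dichlorophenyl for 2-methoxyphenyl gives a 6.1-fold higher number from compound 1 to compound 3 (0.78 log units; beyond the scatter), so among the compounds with a number, the dichlorophenyl form holds the lower value. No measurement on hand explains either result.

Open, on these data alone, is how an unsubstituted phenyl, a 2-chlorophenyl or a ring bearing a carboxylic acid would read at this place in this assay. Also open, as far as these compounds go, is whether the gap between compound 1 and compound 3 tracks the chlorine atoms or the methoxy group.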